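This account rests on a few compounds, and the source may have more. Where it says the series, first, only, none or still open, it means among the compounds named here.

In a functional assay on KYSE-450 cells (Homo sapiens) for inhibition, read by MTT assay, with a stated time of 48 h (on this read-out higher numbers stand for weaker inhibition and lower numbers for stronger inhibition), compound 1 `COc1ccc(CN(C(C)=O)c2cc(OC)c(OC)c(OC)c2)cc1O` stands with the lowest of the two numbers shown, giving 160 nM. For the measured compounds named here, the only other compound with a number is compound 2 `COC(=O)c1cc(CNc2cc(OC)c(OC)c(OC)c2)ccc1OC`, which gives 41100 nM, far beyond the usual scatter from the value of compound 1. Compound 3 `COc1cc(NCc2ccc(Br)cc2)cc(OC)c1OC` gives only > 80000 nM, a limit of this assay rather than a number; it is the limit of > 80000 nM in this assay, at which 1 of the 3 values shown sits.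

Compound 4 `COc1ccc(CN(C(=O)/C=C/CBr)c2cc(OC)c(OC)c(OC)c2)cc1O` has not yet been measured. Compared with compound 1 it carries a different group on the carbonyl carbon whose other neighbour is the amide-type nitrogen: 3-bromoprop-1-en-1-yl in place of methyl on a carbonyl carbon. Cut one bond further out, the change reads acetyl to (3-bromoprop-1-en-1-yl)carbonyl.

Going by the values given here, no pair of measured compounds differs in one place, so no measured step gives a scale for this change. Because compound 1 gives 160 nM, the expectation for compound 4 rests on that value alone. The step of a 1.5-fold lower number from compound 1 to compound 4 (0.16 log units; within the scatter) is expected to stay within the usual scatter, or at most to move modestly toward a lower number, with a wide allowance in either direction. Compound 4 is therefore estimated at 110 nM, with a range from 25 nM to 600 nM.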

Compound 4, half-maximal inhibitory concentration: 100 nM
For compound 4 the middle estimate is 1.1-fold (0.04 log units) above the measured one; low and high end bracket the measured number.
By their numbers in this assay, from the lowest: compounds 4 and 1 (each within the scatter of the next); then compound 2. At a limit, above all of these: compound 3.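

In this assay, putting 3-bromoprop-1-en-1-yl in place of methyl on a carbonyl carbon whose other neighbour is the amide-type nitrogen gives a 1.6-fold lower number from compound 1 to compound 4 (0.20 log units; within the scatter). For the compounds shown here, this is the first step measured between two compounds that differ in one place, and it shows that the core of compound 1 keeps its activity when this much larger group, with its double bond and bromine, replaces methyl, while no gain can be claimed from a difference of this size. No measurement shown here bears on what lies behind this result.

The compounds shown leave open whether the bromine or the double bond matters at all, as a chlorine or a dimethylamino group at the end of the same chain, or a saturated 3-bromopropyl chain, would be needed to separate the two. Going by these compounds, it also remains open how far this place tolerates other kinds of group, such as a longer chain, an amine or a carboxylic acid on the same carbonyl carbon.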